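Swapping bromine for a nitrooxy group on a paw-edema series

The source may report more compounds than this note shows. Statements on the series, on what has been measured and on what is new or still open speak of the compounds shown alone.

Of the compounds shown here, two of one shared core have been measured in a functional assay on the whole organism (strain albino) for inhibition, with Rattus norvegicus as the target, read by paw edema, with stated times of 30 min and 1 h, at a dose of 100 mg/kg by the oral route; a higher number here means more inhibition at the dose given (going by the name of the read-out), a lower number less inhibition. Compound 1, `COc1ccc(C2=NN(C(=O)CBr)C(c3ccco3)C2)cc1OC`, gives 38% there. Compound 2, `COc1ccc(C2=NN(C(=O)C(C)Br)C(c3ccco3)C2)cc1OC`, gives 22% in this assay. Going by the values given here, the only step measured so far is a number 16 percentage points lower from compound 1 to compound 2 (beyond the scatter). Among the compounds with values here, compound 2 thus holds the lowest of the two numbers, its sole neighbour being compound 1 with the higher reading. Compound 3, `COc1ccc(C2=NN(C(=O)C(C)O[N+](=O)[O-])C(c3ccco3)C2)cc1OC`, differs from compound 2 in one place: nitrooxy in place of bromo on a saturated chain carbon bound to a carbonyl carbon and a saturated chain carbon. Within the data shown here, no measured step covers this kind of change; the single known step concerns a methyl group and not the bromine, so it offers no guide to the size or direction of the move. For compound 3 the step of no change at the digits printed from compound 2 to compound 3 (within the scatter) is therefore expected to stay within the scatter. Compound 3 is estimated to give 22% in this assay, with a range from 5% to 40%.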

Compound 3, a percentage reported as inhibition, in the whole organism at one dose (the size of the read-out at that dose, not a potency): 35%
Beside the measured number, compound 3's estimate is 13 percentage points below it, and the stated range covers the measured number.
By their numbers in this assay, from the lowest: compound 2; then compounds 3 and 1 (each within the scatter of the next).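

The bromine on this carbon can be exchanged in this assay with a clear gain, since nitrooxy in place of bromo gives a number 13 percentage points higher from compound 2 to compound 3 (beyond the scatter) on the chain that carries the methyl. The drop seen on adding that methyl therefore does not hold once the bromine has gone, and the change from bromomethyl to 1-(nitrooxy)ethyl gives a number 3 percentage points lower from compound 1 to compound 3 (within the scatter) as its net result. No measurement at hand explains why the reading moves.

Still open, as far as these compounds go, is what an amine or a carboxylic acid would do on this same carbon, and whether nitrooxymethyl, which has no methyl on the chain, would read differently from compound 1. All these readings come from a single dose, so they say nothing about potency.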